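Swapping a fluorophenyl arm for trimethoxyphenyl

This account rests on a few compounds, and the source may have more. Where it says the series, first, only, none or still open, it means among the compounds named here.

Measured so far in a functional assay on QGY-7703 cells (Homo sapiens) for cytotoxicity, read by MTT assay, with a stated time of 24 h; a higher number here means a weaker inhibitor, a lower number a stronger inhibitor
- compound 1 `O=C1/C(=C/c2ccccc2F)CN(S(=O)(=O)c2ccc(F)cc2)C/C1=C\c1ccccc1F` gives 8500 nM
- compound 2 `COc1cc(/C=C2\CN(S(=O)(=O)c3ccc(F)cc3)C/C(=C\c3cc(OC)cc(OC)c3)C2=O)cc(OC)c1` gives 11400 nM
- compound 3 `CC(=O)Nc1ccc(S(=O)(=O)N2C/C(=C\c3ccccc3F)C(=O)/C(=C/c3ccccc3F)C2)cc1` gives 5500 nM

On these numbers, compound 1 lies within the usual scatter of both compound 2 and compound 3, so it holds no clear rank among them. Compound 4 `COc1cc(/C=C2\CN(S(=O)(=O)c3ccc(F)cc3)C/C(=C\c3ccccc3F)C2=O)cc(OC)c1OC` differs from compound 1 by one change 3,4,5-trimethoxyphenyl in place of 2-fluorophenyl on a double-bonded chain carbon bound to a double-bonded ring carbon and this is 3,4,5-trimethoxyphenyl in place of 2-fluorophenyl on a double-bonded chain carbon bound to a double-bonded ring carbon. Within the data shown here, no measured step makes exactly this change. Among the measured compounds shown here, the one step available a 1.5-fold lower number from compound 1 to compound 3 (0.19 log units; within the scatter) lies within the scatter and sits elsewhere in the molecule, with acetamido in place of fluoro on an aromatic carbon. A closer guide is compound 2, whose 2-fluorophenyl groups are replaced by methoxy-bearing phenyl rings. Compound 2 gives 11400 nM while compound 1 gives 8500 nM and that gap is within the scatter. No step beyond the scatter is therefore expected in this assay for this change. The expected step of a 1.1-fold higher number from compound 1 to compound 4 (0.02 log units; within the scatter) stays within the scatter. For compound 4 the estimated value is 9000 nM with an expected range from 4500 nM to 18000 nM as the likely span.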

Compound 4, half-maximal inhibitory concentration: 13300 nM
Compound 4: middle estimate off by 1.5-fold (0.17 log units), on the low side; the measured number falls inside the stated range.
By their numbers in this assay, from the lowest: compounds 3, 1, 2 and 4 (each within the scatter of the next, the first and the last beyond it).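

In this assay, among these compounds, this is the first reading of a single arm changed on its own, with the rest of the molecule held as it is: the step is a 1.6-fold higher number from compound 1 to compound 4 (0.19 log units; within the scatter). On a double-bonded chain carbon bound to a double-bonded ring carbon, then, 3,4,5-trimethoxyphenyl, with 12 heavy atoms, can stand in place of 2-fluorophenyl, with 7, without a change that clears the usual scatter of this cell test. No measurement at hand gives a reason for this result.

As far as these compounds go, whether an arm carrying an amine or a carboxylic acid at this place would move the number beyond the scatter remains open. So does whether the same swap would give a similar step with the acetamido group of compound 3 in place of the fluoro.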